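Geometry of a Drawn Double Bond: Compound 2 to Compound 3

The compounds below may be only part of what the source reports. "The series", "measured", "known", "first", "only" and "open" are said of these compounds alone.

Two compounds have been measured so far:
compound 1, `C/C(=N/NC(=S)Nc1ccccc1I)c1ccccn1`, gives 8.09 nM in a functional assay on T98G cells (Homo sapiens) for cytotoxicity, read by MTT assay, with a stated time of 48 h; on this read-out lower numbers stand for stronger inhibition and higher numbers for weaker inhibition;
compound 2, `C/C(=N\NC(=S)Nc1ccccc1)c1ccccn1`, gives 6.81 nM in this assay.

Compound 2 carries an unsubstituted phenyl ring on the thiourea, whereas compound 1 carries an iodine on that ring. On the numbers shown, compound 2 and compound 1 sit within the scatter of each other, so the two cannot be told apart with confidence and neither can be called the more potent.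

The next compound, compound 3, `C/C(=N/NC(=S)Nc1ccccc1)c1ccccn1`, shares every atom and bond with compound 2 (the two compounds have the same atoms and bonds and differ only in configuration as drawn: 1 of 1 stereo elements differ; a double bond is drawn E in compound 2 and Z in compound 3). Within the data shown here, no measured pair yet shows what such a change in drawn configuration does in this assay. With the iodine change between compound 1 and compound 2 already falling inside the scatter, a step of at most that size, in no particular direction, is the reasonable expectation here; compound 3 is therefore expected to land close to compound 2, with an estimated step of a 1.0-fold higher number from compound 2 to compound 3 (0.01 log units; within the scatter). For compound 3 the estimate in this assay is 7 nM, within a range from 3 nM to 16 nM.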

Compound 3, half-maximal inhibitory concentration: 6.81 nM
Compound 3: middle estimate off by 1.0-fold (0.01 log units), on the high side, and the stated range covers the measured number.
By their numbers in this assay, from the lowest: compounds 2, 3 and 1 (each within the scatter of the next).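

In this assay, among these compounds, the first pair to isolate the drawn configuration of the double bond shows no change at the digits printed from compound 2 to compound 3 (within the scatter), so drawing that bond E or Z makes no visible difference to the read-out. The absence of any visible change may be due to the one thing that separates the two structures: the fact that compounds 2 and 3 differ only in the configuration as drawn. Compounds 1 and 2 differ in both the iodine and the drawn configuration, whereas compounds 1 and 3 isolate the iodine, and hydrogen in place of iodo on an aromatic carbon gives a 1.2-fold lower number from compound 1 to compound 3 (0.07 log units; within the scatter), so this swap also cannot be told apart from the ordinary spread of repeated measurements.

From the compounds shown here alone, the comparison on the phenyl ring covers only hydrogen and iodo, so it remains open whether an amine or a carboxylic acid on that aromatic carbon would also leave the number in place. Going by these compounds, it is also open whether the drawn configuration would remain without visible effect in a compound with a longer chain in place of the methyl group on the double bond.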